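Chloro to Sulfamoyl: One Change on Two Scaffolds

The compounds below may be only part of what the source reports. "The series", "measured", "known", "first", "only" and "open" are said of these compounds alone.

Compound 1 `COc1ccc(-c2nn(-c3ccc(Cl)cc3)cc2/C=N\c2ccc(Cl)cc2)cc1` and compound 2 `COc1ccc(-c2nn(-c3ccc(S(N)(=O)=O)cc3)cc2/C=N\c2ccc(Cl)cc2)cc1` share one core and differ in a single spot. In a functional assay on the whole organism (strain Wistar albino) for inhibition, with Rattus norvegicus as the target, read by paw edema, with stated times of 1 h and 2 h, at a dose of 0.32 mmol/kg by the intraperitoneal route (a higher number here means more inhibition at the dose given (going by the name of the read-out), a lower number less inhibition), compound 1 gives 69.6% and compound 2 gives 63%. The change between them, (sulfamoyl in place of chloro on an aromatic carbon), produced a number 6.6 percentage points lower from compound 1 to compound 2 (within the scatter).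

Compound 3 `Cc1ccc(-c2nn(-c3ccc(Cl)cc3)cc2-c2cc(-c3ccc(Cl)cc3)[nH]c2-c2ccc(F)cc2)cc1` is built on a different core; the difference between the two cores is not broken down here. In this assay compound 3 gives 38.3%, the lowest of the three numbers. Compound 4 `Cc1ccc(-c2nn(-c3ccc(S(N)(=O)=O)cc3)cc2-c2cc(-c3ccc(Cl)cc3)[nH]c2-c2ccc(F)cc2)cc1` is not yet measured; it is obtained from compound 3 by the same change, (sulfamoyl in place of chloro on an aromatic carbon), at the same kind of position.

Because the earlier step of a number 6.6 percentage points lower from compound 1 to compound 2 (within the scatter) stayed within the scatter, the next step is expected to be small as well, estimated as a number 4.3 percentage points lower from compound 3 to compound 4 (within the scatter). This rests on one measured pair only, so the expectation is loose. Compound 4 is therefore expected to reach about 34% in this assay, with a likely range from 22% to 46%.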

Compound 4, a percentage reported as inhibition, in the whole organism at one dose (the size of the read-out at that dose, not a potency): 75.4%
Estimate against measurement, compound 4: 41.4 percentage points below; measured number outside the range, above it.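

Putting sulfamoyl in place of chloro, which turns a 4-chlorophenyl into a 4-sulfamoylphenyl, gave a number 37.1 percentage points higher from compound 3 to compound 4 (beyond the scatter) in this assay, while the same change on the core of compound 1 gave a number 6.6 percentage points lower from compound 1 to compound 2 (within the scatter). The size of this change therefore did not carry over from one core to the other, and a step measured on one core was a poor guide to the step on the other: the same change on two cores in this assay, a number 6.6 percentage points lower (within the scatter) from compound 1 to compound 2 and a number 37.1 percentage points higher (beyond the scatter) from compound 3 to compound 4, 43.7 percentage points apart, beyond the scatter of two such steps. Among these compounds, this does not show why the two cores respond so differently, and with only two pairs, each read at a single dose, it does not establish a general rule for either core or say anything about potency.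

The compounds shown leave open which part of the core of compound 3 goes with the large step. They also leave open whether a carboxylic acid or an amine in place of the sulfamoyl would produce a similar step on that core.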